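A few compounds are considered here, and "the series" means these few. Any claim that something is new, unique, unknown or untested is made for them only; others in the source may bear on it.

In a functional assay on the whole organism (stomach) with Rattus norvegicus as the target (on this read-out higher numbers stand for an effect only at larger amounts of compound and lower numbers for an effect already at smaller amounts), compound 3 `CN(C)/C(=N/CCCCn1nc(-c2ccccc2)ccc1=O)NC#N` gives 30.3 mg/kg, the only plain number among the three results shown. Compound 1 `O=c1ccc(-c2ccccc2)nn1CCCCNC(=S)Nc1ccc(Cl)cc1` reaches only the limit of the assay, > 100 mg/kg. Compound 2 `C/N=C(/NC#N)NCCCCn1nc(N(C)C)ccc1=O` likewise reaches only that limit, > 100 mg/kg. Among the measured compounds shown here, two of the three results thus sit at the limit of > 100 mg/kg in this assay, at which 2 of the 3 values shown sit, leaving compound 3 as the sole anchor for any comparison. Compound 4 `CC(C)(C)/N=C(\S)NCCCCn1nc(-c2ccccc2)ccc1=O` carries a group of 8 heavy atoms (5 carbon, 2 nitrogen, 1 sulfur; no ring) in place of a group of 8 heavy atoms (4 carbon, 4 nitrogen; no ring), on a saturated chain carbon, four bonds along the chain from an aromatic nitrogen. No change of this kind has been measured among these compounds, so neither the size nor the direction of its effect is known from them. The expected step from compound 3 to compound 4 is a 1.3-fold higher number from compound 3 to compound 4 (0.12 log units; within the scatter), a shift of uncertain sign. Compound 4 is therefore expected to give about 40 mg/kg, within a range from 15 mg/kg to 110 mg/kg.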

Compound 4, dose for half-maximal effect: > 100 mg/kg
Compound 4: a limit, no number (the forecaster's own chance of this, stated with the estimate: 40%); at least 2.5-fold (0.39 log units) between middle value and limit.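

The change on a saturated chain carbon, four bonds along the chain from an aromatic nitrogen, now has a measured direction: a group of 8 heavy atoms (5 carbon, 2 nitrogen, 1 sulfur; no ring) in place of a group of 8 heavy atoms (4 carbon, 4 nitrogen; no ring) gives an at least 3.3-fold higher number from compound 3 to compound 4 (0.51 log units; beyond the scatter) in this assay. On these data alone, the result for compound 4 is a limit, not a number, so the true size of this step is unknown. Compound 3 remains the only compound with a plain number: the limit of > 100 mg/kg in this assay, at which 3 of the 4 values shown sit.

The compounds shown leave open which part of the entering group matters, the sulfur or the tert-butyl. They also leave open whether a urea with a carbonyl in place of the sulfur, or a shorter chain, would give an effect at smaller amounts.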